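Replacing isopropylcarbamoyl with 3-(2-methoxyethoxy)propyl on the shared core

The compounds below may be only part of what the source reports. "The series", "measured", "known", "first", "only" and "open" are said of these compounds alone.

In an ADME assay on CEM-SS cells (Homo sapiens) for cytotoxicity, read by XTT assay (a higher number here means that more compound is tolerated, a lower number that less compound is tolerated), compound 3 (`CC(C)NC(=O)c1cn(Cc2ccc(F)cc2)c2cnc(C(=O)N(C)O)cc12`) gives > 100000 nM, which is a limit and not a number. Compound 2 (`CN(O)C(=O)c1cc2c(C(=O)N3CCC[C@@H]3CO)cn(Cc3ccc(F)cc3)c2cn1`) gives > 32000 nM, also a limit. Only compound 1 (`COCc1cn(Cc2ccc(F)cc2)c2cnc(C(=O)N(C)O)cc12`), which carries methoxymethyl at this aromatic carbon, has a number, 266000 nM.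

Compound 4 (`COCCOCCCc1cn(Cc2ccc(F)cc2)c2cnc(C(=O)N(C)O)cc12`) has 3-(2-methoxyethoxy)propyl in place of isopropylcarbamoyl on an aromatic carbon.

The measured steps at this carbon give no size: a step that the limit leaves unreadable from compound 1 to compound 3, a step that the limit leaves unreadable from compound 1 to compound 2 and a step that the two limits leave unreadable from compound 2 to compound 3. The only numerical anchor is therefore compound 1 at 266000 nM, and its side chain is also the one closest to the entering chain. In this assay, compound 4 is expected to sit near compound 1, with no firm direction from compound 3 and a fair chance of another limit. The expected change is a step that the limit leaves unreadable from compound 3 to compound 4. The estimate for compound 4 is 150000 nM, with an expected range of 40000 nM to 400000 nM.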

Compound 4, half-maximal cytotoxic concentration: > 10000 nM
Compound 4 ended at the assay's limit; the forecaster's own chance of this, stated with the estimate: 45%; the middle value is on the limit's open side.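

In this assay compound 4 gives > 10000 nM, a limit and not a number. Among these compounds, no step from compound 1, compound 2 or compound 3 to compound 4 can be read. The compounds shown leave open whether 3-(2-methoxyethoxy)propyl tolerance differs from that of compound 1, and in which direction.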